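The source may report more compounds than this note shows. Statements on the series, on what has been measured and on what is new or still open speak of the compounds shown alone.

The compounds measured in an ADME assay on NIH3T3 cells (Mus musculus) for cytotoxicity, read by MTT assay, with a stated time of 24 h (on this read-out higher numbers stand for weaker inhibition and lower numbers for stronger inhibition), are these.
Compound 1 `O=C(CN1CCN(c2cccc(Cl)c2)CC1)N1CCN(c2nnc(-c3ccccc3)c(-c3ccccc3)n2)CC1` gives 178000 nM.
Compound 2 `COc1ccc(N2CCN(CC(=O)N3CCN(c4nnc(-c5ccccc5)c(-c5ccccc5)n4)CC3)CC2)cc1` gives only a limit of the assay, > 910000 nM.
Compound 3 `O=C(CN1CCN(c2cccc(Cl)c2)CC1)N1CCN(c2nnc(-c3ccc(Cl)cc3)c(-c3ccc(Cl)cc3)n2)CC1` gives only a limit of the assay, > 803000 nM.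

The core of compound 1 and the core of compound 3 are not the same, and the difference between the two cores is not broken down here. Compound 1 and compound 2 differ in one place, (4-methoxyphenyl in place of 3-chlorophenyl on an amine nitrogen in a ring). That change produced the step of an at least 5.1-fold higher number from compound 1 to compound 2 (0.70 log units; beyond the scatter). The value of compound 2 is a limit of the assay, (the limit of > 910000 nM in this assay, at which 1 of the 3 values shown sits), so the step can only be given as a lower bound.

Compound 4 `COc1ccc(N2CCN(CC(=O)N3CCN(c4nnc(-c5ccc(Cl)cc5)c(-c5ccc(Cl)cc5)n4)CC3)CC2)cc1` has not yet been measured in this assay. It stands to compound 3 as compound 2 stands to compound 1, differing in one place, (4-methoxyphenyl in place of 3-chlorophenyl on an amine nitrogen in a ring). The surroundings of the place are the same word for word in both cases, so this is the same change made on a second core. Compound 3 already sits at a limit of the assay, (the limit of > 803000 nM in this assay, at which 1 of the 3 values shown sits), so no numbered value is available as a starting point.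

The expected step is a step that the limit leaves unreadable from compound 3 to compound 4, which rests on the earlier step of an at least 5.1-fold higher number from compound 1 to compound 2 (0.70 log units; beyond the scatter) and on compound 3 standing at the limit of > 803000 nM in this assay, at which 1 of the 3 values shown sits. Compound 4 is estimated at 1200000 nM. For compound 4 the expected range runs from 500000 nM to 4000000 nM, and it is expected that the assay will most likely report only a limit for compound 4.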

Compound 4, half-maximal inhibitory concentration: > 809000 nM
Compound 4 ended at the assay's limit (the forecaster's own chance of this, stated with the estimate: 85%); the middle value is on the limit's open side.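

Compound 3 and compound 4 both stand at limits of this assay, so no step can be read between them, and the change from 3-chlorophenyl to 4-methoxyphenyl has no readable size on this core. The compounds shown leave open whether that change shifts the number on the core of compound 3 as it does on the core of compound 1.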